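A few compounds are considered here, and "the series" means these few. Any claim that something is new, unique, unknown or untested is made for them only; others in the source may bear on it.

Three compounds have so far been measured in an ADME assay for metabolic stability, read by HPLC, at pH 7.4; a higher number here means that the compound lasts longer, a lower number that the compound disappears faster:
compound 1 `CCCCCCNC(=O)Oc1ccc(Cl)cc1C(=O)Nc1cccc(Cl)c1` gives 43 h;
compound 2 `CCCCCCCNC(=O)Oc1ccc(Cl)cc1C(=O)Nc1cccc(Cl)c1` gives 43 h;
compound 3 `CCCCCCNC(=O)Oc1ccc(Cl)cc1C(=O)Nc1ccc(Cl)cc1` gives 43 h.

Compound 1 and compound 2 differ by methyl in place of hydrogen on a saturated chain carbon, six bonds along the chain from an amide-type nitrogen, and that step is no change at the digits printed from compound 1 to compound 2 (within the scatter). The cores of compound 1 and compound 3 differ by 4-chlorophenyl in place of 3-chlorophenyl on an amide-type nitrogen, with a step of no change at the digits printed from compound 1 to compound 3 (within the scatter). Compound 4 `CCCCCCCNC(=O)Oc1ccc(Cl)cc1C(=O)Nc1ccc(Cl)cc1` has not yet been measured in this assay. It stands to compound 3 as compound 2 stands to compound 1, the difference being (methyl in place of hydrogen on a saturated chain carbon, six bonds along the chain from an amide-type nitrogen), the same change at the same place. Compound 1 gives 43 h and its step to compound 2 is no change at the digits printed from compound 1 to compound 2 (within the scatter). On that footing the step from compound 3 to compound 4 is expected to be no change at the digits printed from compound 3 to compound 4 (within the scatter). Compound 4 is therefore estimated at 43 h in this assay, expected to lie between 22 h and 86 h.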

Compound 4, half-life: 43 h
Compound 4: middle estimate and measured number agree at the digits printed; low and high end bracket the measured number.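

In this assay, methyl in place of hydrogen on a saturated chain carbon gives no change at the digits printed from compound 3 to compound 4 (within the scatter), which matches the earlier step on the other core: the same change on two cores in this assay, no change at the digits printed (within the scatter) from compound 1 to compound 2 and no change at the digits printed (within the scatter) from compound 3 to compound 4, 1.0-fold (0.00 log units) apart, within the scatter of two such steps. Likewise, 4-chlorophenyl in place of 3-chlorophenyl on an amide-type nitrogen gives no change at the digits printed from compound 2 to compound 4 (within the scatter), again matching the earlier step: the same change on two cores in this assay, no change at the digits printed (within the scatter) from compound 1 to compound 3 and no change at the digits printed (within the scatter) from compound 2 to compound 4, 1.0-fold (0.00 log units) apart, within the scatter of two such steps. This shows that both changes carry between these cores without moving the reading, but it does not show that a change with a real effect on the half-life would carry over in the same way.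

On these data alone, it remains open how the half-life would respond to a longer chain or to an amine or a carboxylic acid on the chain. A nitrile in place of the chlorine on either ring is also untested among the compounds shown.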